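This account rests on a few compounds, and the source may have more. Where it says the series, first, only, none or still open, it means among the compounds named here.

Compound 1 `COc1cc(NC(C)CCCNC(=O)Nc2cccc(F)c2)c2ncccc2c1`: 18000 nM
Compound 2 `COc1cc(NC(C)CCCNC(=O)NNC(=O)Nc2ccc(Cl)cc2)c2ncccc2c1`: 180 nM
Compound 3 `COc1cc(NC(C)CCCNC(=O)Nc2cccc(O)c2)c2ncccc2c1`: 11000 nM

In a functional assay on MCF7 cells (Homo sapiens) for inhibition, read by MTT assay, with a stated time of 72 h (a higher number here means a weaker inhibitor, a lower number a stronger inhibitor), compound 3 stands with compound 1 and well above compound 2. Compound 4 `COc1cc(NC(C)CCCNC(=O)Nc2ccc(Cl)cc2)c2ncccc2c1` carries 4-chlorophenyl in place of 3-hydroxyphenyl on an amide-type nitrogen.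

For the measured compounds named here, the closest precedent is an exchange on the same aromatic ring, a 1.6-fold lower number from compound 1 to compound 3 (0.21 log units; within the scatter). The large steps, a 100-fold lower number from compound 1 to compound 2 (2.00 log units; beyond the scatter) and a 61-fold higher number from compound 2 to compound 3 (1.79 log units; beyond the scatter), both involve the ((4-chlorophenyl)carbamoyl)amino group, which compound 4 lacks, so they say little here. No step beyond the scatter is therefore expected in this assay.

The expected step is a 1.2-fold higher number from compound 3 to compound 4 (0.07 log units; within the scatter).

Compound 4 is estimated at 13000 nM, with an expected range of 4500 nM to 38000 nM.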

Compound 4, half-maximal inhibitory concentration: 12000 nM
Compound 4: the middle estimate sits 1.1-fold (0.03 log units) above what was measured; the measured number falls inside the stated range.
By their numbers in this assay, from the lowest: compound 2; then compounds 3, 4 and 1 (each within the scatter of the next).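

In this assay the aromatic group on the amide-type nitrogen shows little sensitivity across these compounds: 4-chlorophenyl in place of 3-hydroxyphenyl gives a 1.1-fold higher number from compound 3 to compound 4 (0.04 log units; within the scatter) and 4-chlorophenyl in place of 3-fluorophenyl gives a 1.5-fold lower number from compound 1 to compound 4 (0.18 log units; within the scatter) without any step beyond the scatter. The 4-chlorophenyl group alone does not reproduce the number of compound 2: with that group kept, the step is a 67-fold higher number from compound 2 to compound 4 (1.82 log units; beyond the scatter) when the carbamoylamino link is absent. No evidence is available to explain these steps.

Open, going by these compounds, is whether the carbamoylamino link keeps its low number with 3-hydroxyphenyl or 3-fluorophenyl at its end. Also open, on these data alone, is whether an amine or a carboxylic acid on the aromatic ring would leave this position equally insensitive.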